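Series notes: methylating the sulfanyl group of compound 2

The source may report more compounds than this note shows. Statements on the series, on what has been measured and on what is new or still open speak of the compounds shown alone.

Measured so far:
Compound 1 `CCCc1cccc(=O)n1Cc1ccc(-c2ccccc2-c2nn[nH]n2)cc1`: 1.1 mg/kg
Compound 2 `CCCc1cc(S)cc(=O)n1Cc1ccc(-c2ccccc2-c2nn[nH]n2)cc1`: 0.017 mg/kg

In a functional assay on the whole organism with Rattus norvegicus as the target (a higher number here means that more compound is needed for the effect, a lower number that less compound is needed), compound 1 gives 1.1 mg/kg, and compound 2 gives 0.017 mg/kg. Among the compounds with values here, the one step measured, sulfanyl in place of hydrogen on an aromatic carbon, is a 65-fold lower number from compound 1 to compound 2 (1.81 log units; beyond the scatter). Within the data shown here, compound 2 therefore stands at the lowest of the two numbers, with compound 1 as its only neighbour, separated by that large step.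

Compound 3 `CCCc1cc(SC)cc(=O)n1Cc1ccc(-c2ccccc2-c2nn[nH]n2)cc1` differs from compound 2 by methyl in place of hydrogen on a sulfur. Among the measured compounds shown here, no measured step alters a substituent on the sulfur; the only step known, a 65-fold lower number from compound 1 to compound 2 (1.81 log units; beyond the scatter), concerns introducing the sulfanyl group itself and bears on this change only loosely. The sulfur is retained, so a step near the scatter is expected in this assay, with the direction uncertain and a drift toward a higher number somewhat more likely than the reverse.

Compound 3 is estimated at 0.03 mg/kg, range 0.006 mg/kg to 0.15 mg/kg, an expected step of a 1.8-fold higher number from compound 2 to compound 3 (0.25 log units; within the scatter).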

Compound 3, dose for 50% inhibition: 0.28 mg/kg
The estimate for compound 3 lay 9.3-fold (0.97 log units) below the measured number; the measured number lies above the stated range.
By their numbers in this assay, from the lowest: compound 2; then compound 3; then compound 1.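

In this assay the substituent on the sulfur proves decisive: methyl in place of hydrogen on a sulfur gives a 16-fold higher number from compound 2 to compound 3 (1.22 log units; beyond the scatter) even though the sulfur itself is retained. Methylsulfanyl in place of hydrogen on an aromatic carbon still gives a 3.9-fold lower number from compound 1 to compound 3 (0.59 log units; beyond the scatter) so part of the gain seen with sulfanyl survives methylation, though most of it is lost. Nothing available bears on the cause of either step.

With methyl as the only substituent on the sulfur, the compounds shown leave open whether a longer chain such as ethyl or propyl there would raise the number further or change it little. They also leave open whether a hydroxyl or an amine on the same aromatic carbon would match sulfanyl or methylsulfanyl.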